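Swapping a urea for a methoxyphenyl on the shared core

The source may report more compounds than this note shows. Statements on the series, on what has been measured and on what is new or still open speak of the compounds shown alone.

Measured compounds:
compound 1, `Nc1ncc(-c2cnn(C3CCNCC3)c2)cc1-c1nc2ccc(Nc3ccc(F)cc3)cc2o1`, 3700 nM
compound 2, `Nc1ncc(-c2cnn(C3CCNCC3)c2)cc1-c1nc2ccc(-c3cn[nH]c3)cc2o1`, 1780 nM
compound 3, `Nc1ncc(-c2cnn(C3CCNCC3)c2)cc1-c1nc2ccc(NC(=O)Nc3ccccc3)cc2o1`, 1660 nM

These three compounds share one core and were tested in an assay on isolated protein for inhibition of G protein-coupled receptor kinase 5 (Homo sapiens), read by TR-FRET, with stated times of 10 min and 1 h; on this read-out higher numbers stand for weaker inhibition and lower numbers for stronger inhibition. Compound 3 gives the lowest number of the three, but its gap to compound 2 lies within the scatter, so the two cannot be ranked; only compound 1 stands apart, as the step of a 2.2-fold lower number from compound 1 to compound 3 (0.35 log units; beyond the scatter) shows.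

Compound 4, `COc1ccc(-c2ccc3nc(-c4cc(-c5cnn(C6CCNCC6)c5)cnc4N)oc3c2)cc1`, has not yet been measured. It differs from compound 3 in one place: 4-methoxyphenyl in place of (phenylcarbamoyl)amino on an aromatic carbon.

Going by the values given here, two measured steps bear on this. The step of a 2.2-fold lower number from compound 1 to compound 3 (0.35 log units; beyond the scatter) changed the group on the same ring nitrogen and gave a modest gain. The step of a 1.1-fold lower number from compound 2 to compound 3 (0.03 log units; within the scatter) swapped a directly attached pyrazolyl for the urea and changed nothing beyond the scatter. Compound 4 again carries a directly attached aromatic ring, like compound 2. On this basis the step of a 1.5-fold higher number from compound 3 to compound 4 (0.18 log units; within the scatter) is expected to stay within the scatter, if anything toward a slightly higher number. Compound 4 is therefore estimated at 2500 nM, with a range from 1000 nM to 6500 nM.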

Compound 4, half-maximal inhibitory concentration: 3220 nM
The estimate for compound 4 lay 1.3-fold (0.11 log units) below the measured number; measured number inside the range.
By their numbers in this assay, from the lowest: compounds 3, 2, 4 and 1 (each within the scatter of the next, the first and the last beyond it).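

In this assay, 4-methoxyphenyl on this aromatic carbon cannot be told apart from any of the three groups tested before it (a 1.9-fold higher number from compound 3 to compound 4 (0.29 log units; within the scatter); a 1.8-fold higher number from compound 2 to compound 4 (0.26 log units; within the scatter); a 1.1-fold lower number from compound 1 to compound 4 (0.06 log units; within the scatter)). The change from (phenylcarbamoyl)amino to 4-methoxyphenyl takes the count of hydrogen-bond donors in this group from 2 to 0 and removes the double bond outside aromatic rings, yet the step stays within the scatter, so this read-out shows no need for the urea's donors or its carbonyl. Compound 4 also lies within the scatter of both compound 1 and compound 3, so it does not add a new level: the only separation among these four compounds remains the modest one between that pair (a 2.2-fold lower number from compound 1 to compound 3 (0.35 log units; beyond the scatter)).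

No measurement shown explains why such different groups read so alike. From the compounds shown here alone, it remains open whether a much smaller group on this carbon, such as a simple amine or a carboxylic acid, or a longer chain ending in a morpholine ring, would move the number beyond the scatter in this assay.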